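A few compounds are considered here, and "the series" means these few. Any claim that something is new, unique, unknown or untested is made for them only; others in the source may bear on it.

Measured so far:
compound 1 `COC(CCNC(=O)Nc1cc2c(Nc3ccc(F)c(Cl)c3)ncnc2cc1O[C@H]1CCOC1)OC` — 22000 nM
compound 2 `CN(C)CCN(C)C(=O)Nc1cc2c(Nc3ccc(F)c(Cl)c3)ncnc2cc1O[C@H]1CCOC1` — 450 nM

The two compounds share one core and differ only in the group attached to the urea carbonyl carbon. In a functional assay on A-431 cells (Homo sapiens) for antiproliferative activity, read by sulforhodamine B assay, with a stated time of 72 h (a lower number here means a stronger inhibitor, a higher number a weaker inhibitor), compound 1 gives 22000 nM, and compound 2 gives 450 nM. Going by the values given here, the step of a 49-fold lower number from compound 1 to compound 2 (1.69 log units; beyond the scatter) is the only comparison available, so compound 2 holds the lower of the two numbers, with compound 1 as its sole neighbour.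

Compound 3 `CCN(CC)CCN(C)C(=O)Nc1cc2c(Nc3ccc(F)c(Cl)c3)ncnc2cc1O[C@H]1CCOC1` has not yet been tested in this assay. Its change from compound 2 is diethylamino in place of dimethylamino on a saturated chain carbon, two bonds along the chain from an amide-type nitrogen. Among the compounds with values here, no measured step covers this exchange: the one step known, a 49-fold lower number from compound 1 to compound 2 (1.69 log units; beyond the scatter), swaps the entire group on the carbonyl carbon rather than the two alkyl groups on the terminal nitrogen, and it was large. The (2-(diethylamino)ethyl)(methyl)amino group of compound 3 keeps the chain and the nitrogen of compound 2 intact. The expectation for compound 3 is therefore a step of no change at the digits printed from compound 2 to compound 3 (within the scatter) in this assay, within the scatter. Compound 3 is estimated at 450 nM, with a range from 150 nM to 1400 nM.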

Compound 3, half-maximal inhibitory concentration: 481 nM
Compound 3: the middle estimate sits 1.1-fold (0.03 log units) below what was measured; measured number inside the range.
By their numbers in this assay, from the lowest: compounds 2 and 3 (each within the scatter of the next); then compound 1.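

In this assay, diethylamino in place of dimethylamino, on a saturated chain carbon, two bonds along the chain from an amide-type nitrogen, gives a 1.1-fold higher number from compound 2 to compound 3 (0.03 log units; within the scatter); this position therefore accepts 5 heavy atoms where 3 stood, with no difference that can be read. The large step away from the (3,3-dimethoxypropyl)amino group also appears with the second amine, as a 46-fold lower number from compound 1 to compound 3 (1.66 log units; beyond the scatter), so it no longer rests on the (2-(dimethylamino)ethyl)(methyl)amino group alone. No measurement shown here accounts for either step.

Compounds 2 and 3 both keep the methyl on the urea nitrogen and the ethyl chain, so the steps from compound 1 do not separate the amine from that methyl or from the chain; a (2-(dimethylamino)ethyl)amino group would make that distinction. From the compounds shown here alone, it also remains open whether a morpholine or pyrrolidine ring at the chain end, or a longer chain between the two nitrogens, would stay in the same range as compounds 2 and 3.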